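Compound 3: hydroxy for chloro on the styryl end

This account rests on a few compounds, and the source may have more. Where it says the series, first, only, none or still open, it means among the compounds named here.

Measured in a functional assay on OVCAR-8 cells (Homo sapiens) (on this read-out higher numbers stand for weaker inhibition of growth and lower numbers for stronger inhibition of growth), so far
- compound 1 (`O=S(=O)(/C=C/c1ccc(O)cc1)Cc1ccc(Nc2ncnc3ccccc23)cc1`) gives 1000 nM
- compound 2 (`O=S(=O)(/C=C/c1ccc(Cl)cc1)Cc1ccc(Nc2ncnc3ccc(Br)cc23)cc1`) gives 3000 nM

Of these two numbers, compound 2 holds the higher, and compound 1 lies lower by more than the scatter. Compound 3 (`O=S(=O)(/C=C/c1ccc(O)cc1)Cc1ccc(Nc2ncnc3ccc(Br)cc23)cc1`) is still unmeasured. It departs from compound 2 in one place, (hydroxy in place of chloro on an aromatic carbon), with hydroxy in place of chloro on an aromatic carbon, para to a large group. For the measured compounds named here, no measured pair isolates this change, and compound 1 and compound 2 differ in more than one place. Going by the values given here, the only guide is compound 1, which also carries the 4-hydroxyphenyl group and gives 1000 nM in the same read-out. The expected change is a 1.9-fold lower number from compound 2 to compound 3 (0.27 log units; within the scatter) in this assay, a modest move to a lower number that may stay within the scatter. For compound 3 the estimated value is 1600 nM within an expected range of 600 nM to 4000 nM pending measurement.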

Compound 3, concentration for 50% growth inhibition: > 100000 nM
Compound 3: only a limit was reported (the forecaster's own chance of this, stated with the estimate: 3%); at least 62-fold (1.79 log units) between middle value and limit.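

In this assay compound 3 reaches only a limit, not a number: the limit of > 100000 nM in this assay, at which 1 of the 3 values shown sits.

With the bromo group held, 4-hydroxyphenyl in place of 4-chlorophenyl gives an at least 33-fold higher number from compound 2 to compound 3 (1.52 log units; beyond the scatter), so this aromatic carbon is far from indifferent to the swap of chloro for hydroxy. With the 4-hydroxyphenyl group held, bromo in place of hydrogen gives an at least 100-fold higher number from compound 1 to compound 3 (2.00 log units; beyond the scatter), so the loss of growth inhibition in this series appears only where hydroxy and bromo occur together, not with hydroxy alone in compound 1 or with bromo alone in compound 2.

As far as these compounds go, whether chloro on the styryl end would read differently without the bromo group remains open, so the two changes cannot yet be judged independently. Also open, from the compounds shown here alone, is how a methoxy group or an amine would read at this same aromatic carbon.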